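Swapping Methoxy for tert-Butyl: What to Expect

This account rests on a few compounds, and the source may have more. Where it says the series, first, only, none or still open, it means among the compounds named here.

Among the compounds with values here, compound 2 `COc1ccc(S(=O)(=O)c2cc3ccccc3n2C)cc1` gives 1120 nM in a functional assay on cells (Peritoneal macrophage, Mus musculus) for inhibition, read by ELISA, with stated times of 30 min and 24 h (on this read-out lower numbers stand for stronger inhibition and higher numbers for weaker inhibition), the lower of the two numbers measured so far. Within the data shown here, compound 1 `Cc1ccc(S(=O)(=O)c2cc3ccccc3n2C)cc1` gives 2390 nM in this assay, and the single measured step is a 2.1-fold lower number from compound 1 to compound 2 (0.33 log units; beyond the scatter). Compound 3 `Cn1c(S(=O)(=O)c2ccc(C(C)(C)C)cc2)cc2ccccc21` differs from compound 2 in one place: tert-butyl in place of methoxy on an aromatic carbon. That one step touches the same position but exchanged two other groups, so it bears only loosely on the new change. For compound 3 a modest step of uncertain direction is expected, a 1.8-fold higher number from compound 2 to compound 3 (0.25 log units; within the scatter). Compound 3 is estimated at 2000 nM, within a range of 700 nM to 6000 nM.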

Compound 3, half-maximal inhibitory concentration: 1100 nM
Compound 3: the middle estimate sits 1.8-fold (0.26 log units) above what was measured; measured number inside the range.
By their numbers in this assay, from the lowest: compounds 3 and 2 (each within the scatter of the next); then compound 1.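

Tert-butyl and methoxy cannot be told apart at this position in this assay (a 1.0-fold lower number from compound 2 to compound 3 (0.01 log units; within the scatter)), so a hydrogen-bond acceptor on this carbon is not needed to reach this level. Tert-butyl in place of methyl gives a modest step beyond the scatter (a 2.2-fold lower number from compound 1 to compound 3 (0.34 log units; beyond the scatter)), so two quite different groups both improve on methyl. Nothing measured here gives a reason for these steps. As far as these compounds go, how an amine, a carboxylic acid or a fluorine atom on this carbon would fare stays open.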